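From Fluoro to Methyl: What to Expect of Compound 4

The source may report more compounds than this note shows. Statements on the series, on what has been measured and on what is new or still open speak of the compounds shown alone.

In a functional assay on KG-1 cells (Homo sapiens) for cytotoxicity, read by luminescence and CellTiter-Glo, with a stated time of 3 days (on this read-out lower numbers stand for stronger inhibition and higher numbers for weaker inhibition), compound 1 `N#Cc1ccc(NC(=O)c2cc(F)ccc2O)cc1` gives 2670 nM as its measured value. Compound 2 `O=C(Nc1ccc(C(F)(F)F)cc1)c1cc(F)ccc1O` has trifluoromethyl in place of cyano on an aromatic carbon and gives 1700 nM as its value. Among the measured compounds shown here, that step is a 1.6-fold lower number from compound 1 to compound 2 (0.20 log units; within the scatter) so these two compounds, the only ones with actual numbers, stand level. Compound 3 `CN(C(=O)c1cc(F)ccc1O)c1ccc(C#N)cc1` has methyl in place of hydrogen on the amide-type nitrogen and reports > 10000 nM as a limit of the assay, not a number. That step is an at least 3.7-fold higher number from compound 1 to compound 3 (0.57 log units; beyond the scatter) and it is the only one that clearly moves the result.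

Compound 4 `Cc1ccc(O)c(C(=O)Nc2ccc(C#N)cc2)c1` differs from compound 1 in one place (methyl in place of fluoro on an aromatic carbon) with methyl in place of fluoro on an aromatic carbon, para to a hydroxy group. Neither measured step touches that place, so both offer only loose guidance. The nearest guide is the swap on an aromatic carbon that gives compound 2 at 1700 nM and stays within the scatter of compound 1, while the larger shift came at the amide-type nitrogen, which compound 4 leaves unchanged. No shift beyond the scatter is therefore expected in this assay and the estimated step is a 1.1-fold higher number from compound 1 to compound 4 (0.05 log units; within the scatter) as a working figure. For compound 4 the expected value is 3000 nM with an estimated range from 1000 nM to 9000 nM overall.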

Compound 4, half-maximal inhibitory concentration: 3370 nM
For compound 4 the middle estimate is 1.1-fold (0.05 log units) below the measured one; the measured number falls inside the stated range.
By their numbers in this assay, from the lowest: compounds 2, 1 and 4 (each within the scatter of the next). At a limit, above all of these: compound 3.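

In this assay, the place para to a hydroxy group now has a change of its own to read, since methyl in place of fluoro gives a 1.3-fold higher number from compound 1 to compound 4 (0.10 log units; within the scatter) and so leaves the result level with that of the fluoro compound. This shows that fluoro is not needed at this place to keep the activity seen with compound 1, and that a carbon group can stand there instead of a halogen without a shift that can be told from the scatter. It also adds a second change on an aromatic carbon to the trifluoromethyl swap, which gave a 1.6-fold lower number from compound 1 to compound 2 (0.20 log units; within the scatter), so both such changes stay within the scatter, while compound 3, with its methyl on the amide-type nitrogen, goes against them; nothing measured here says why this swap leaves the number where it stands.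

Among the compounds shown, only fluoro and methyl occupy this place, so the effect of an amine, a carboxylic acid or a longer chain such as propyl there remains open. Also open, as far as these compounds go, is whether methyl at this place would behave the same way with trifluoromethyl in place of the nitrile.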